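A few compounds are considered here, and "the series" means these few. Any claim that something is new, unique, unknown or untested is made for them only; others in the source may bear on it.

Two close relatives open the set. Compound 1 `COc1cc(OCC=C(C)C)ccc1C(=O)/C=C/c1ccncc1` carries a pyridin-4-yl ring at the end of its double-bonded chain, and compound 2 `COc1cc(OCC=C(C)C)ccc1C(=O)/C=C/c1cccnc1` carries a pyridin-3-yl ring at the same spot; the change between them is pyridin-3-yl in place of pyridin-4-yl on a double-bonded chain carbon bound to a double-bonded chain carbon. In an ADME assay on Vero cells (Chlorocebus sabaeus) for cytotoxicity, read by resazurin assay, with a stated time of 72 h (on this read-out higher numbers stand for lower toxicity in this test and lower numbers for higher toxicity in this test), compound 1 gives 16000 nM, and in the same test compound 2 gives 22000 nM, so a 1.4-fold higher number from compound 1 to compound 2 (0.14 log units; within the scatter).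

Compound 3 `C#CCOc1ccc(C(=O)/C=C/c2ccncc2)c(OCC#C)c1` is built on a different core, and how that core differs from the core of compound 1 is not broken down here. In this assay compound 3 gives 10000 nM. Its gap to compound 1 lies within the usual scatter of repeated measurements, while its gap to compound 2 lies beyond it, so compound 3 reads as more toxic in this test than compound 2.

Compound 4 `C#CCOc1ccc(C(=O)/C=C/c2cccnc2)c(OCC#C)c1` stands to compound 3 exactly as compound 2 stands to compound 1: the change is pyridin-3-yl in place of pyridin-4-yl on a double-bonded chain carbon bound to a double-bonded chain carbon, made at the same place as before. Within the data shown here, with only one earlier measured example of this change, the expectation for compound 4 rests on compound 1 and compound 2, where a 1.4-fold higher number from compound 1 to compound 2 (0.14 log units; within the scatter). Compound 4 is therefore expected to give about 14000 nM, with a likely range from 8000 nM to 25000 nM. The expected step is a 1.4-fold higher number from compound 3 to compound 4 (0.15 log units; within the scatter).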

Compound 4, half-maximal cytotoxic concentration: 6000 nM
Compound 4: middle estimate off by 2.3-fold (0.37 log units), on the high side; measured number below the stated range.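

In this assay, pyridin-3-yl in place of pyridin-4-yl on the core of compound 3 gives a 1.7-fold lower number from compound 3 to compound 4 (0.22 log units; within the scatter), and set beside the earlier example of the same change, this step does not differ from it: the same change on two cores in this assay, a 1.4-fold higher number (0.14 log units; within the scatter) from compound 1 to compound 2 and a 1.7-fold lower number (0.22 log units; within the scatter) from compound 3 to compound 4, 2.3-fold (0.36 log units) apart, within the scatter of two such steps. As far as these two pairs go, the change behaves the same on both cores within the limits of the test, and on neither core does it shift the number clear of the usual scatter of repeated measurements. This does not show that the change has no effect at all or that the two cores respond identically, since two small steps could still hide a modest real difference, and two pairs say nothing about how the change would read on a third core.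

The compounds shown hold only these two pyridine rings at the end of the chain, so they leave open how pyridin-2-yl, a plain phenyl ring or a pyridine ring carrying an amine would read in this test on either core. They also leave open what a longer chain between the carbonyl and the ring would do to the cytotoxicity number.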